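Azido in place of methylsulfonyl on two cores

A few compounds are considered here, and "the series" means these few. Any claim that something is new, unique, unknown or untested is made for them only; others in the source may bear on it.

All three measured compounds were run in an ADME assay on L6 cells (Rattus norvegicus) for inhibition, read by resazurin assay, with a stated time of 72 h (a higher number here means a weaker inhibitor, a lower number a stronger inhibitor), and their numbers stand as follows.

Compound 1, `CC(=O)O[C@@H]1[C@H](OC(C)=O)[C@@H](CS(C)(=O)=O)O[C@H]1n1cnc2c(N)nc(Cl)nc21`: 114000 nM.
Compound 2, `CS(=O)(=O)C[C@H]1O[C@@H](n2cnc3c(N)nc(F)nc32)[C@H](O)[C@@H]1O`: 5000 nM.
Compound 3, `CC(=O)O[C@@H]1[C@H](OC(C)=O)[C@@H](CN=[N+]=[N-])O[C@H]1n1cnc2c(N)nc(Cl)nc21`: 141000 nM.

Compound 1 and compound 3 share one core and differ only by azido in place of methylsulfonyl on a saturated chain carbon bound to a saturated ring carbon. This change gave a 1.2-fold higher number from compound 1 to compound 3 (0.09 log units; within the scatter), so on this core the two groups behave alike in this assay.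

Compound 2 has the lowest of the three numbers, and its gap to compound 1 and to compound 3 is in each case beyond the scatter. How the core of compound 2 differs from the core of compound 1 is not broken down here.

Compound 4, `[N-]=[N+]=NC[C@H]1O[C@@H](n2cnc3c(N)nc(F)nc32)[C@H](O)[C@@H]1O`, is not yet measured in this assay. It is related to compound 2 by azido in place of methylsulfonyl on a saturated chain carbon bound to a saturated ring carbon. The place of this change reads word for word as in the pair of compound 1 and compound 3, so it is the same change, made once on each core.

The expectation for compound 4 rests on one measured step only. Because a 1.2-fold higher number from compound 1 to compound 3 (0.09 log units; within the scatter) stayed within the scatter, the step from compound 2 is expected to be small as well, estimated as a 1.2-fold higher number from compound 2 to compound 4 (0.08 log units; within the scatter). Compound 4 is accordingly estimated at 6000 nM in this assay, with the likely range put between 2500 nM and 15000 nM. Going by the values given here, compound 2 is the only anchor for this number, and the one measured step comes from a different core, so the range is kept wide.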

Compound 4, half-maximal inhibitory concentration: 3100 nM
Compound 4: the middle estimate sits 1.9-fold (0.29 log units) above what was measured, and the stated range covers the measured number.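

In this assay, azido in place of methylsulfonyl on a saturated chain carbon bound to a saturated ring carbon gave a 1.6-fold lower number from compound 2 to compound 4 (0.21 log units; within the scatter), so the two groups cannot be told apart on the core of compound 2. Set beside the earlier step, the change carries from one core to the other without a difference that can be resolved: the same change on two cores in this assay, a 1.2-fold higher number (0.09 log units; within the scatter) from compound 1 to compound 3 and a 1.6-fold lower number (0.21 log units; within the scatter) from compound 2 to compound 4, 2.0-fold (0.30 log units) apart, within the scatter of two such steps This shows only that the swap left the number within the scatter on these two cores in this one assay; it does not show that the two groups are equivalent, since a small real effect could lie hidden in the scatter, and two pairs do not establish that the result holds on any further core or in any other assay.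

Open, as far as these compounds go, is whether an amine, a carboxylic acid or a longer chain at the same place would also stay within the scatter of methylsulfonyl and azido, or whether the tolerance is limited to these two groups. Also open is which part of the difference between the two cores sets compound 2 and compound 4 apart from compound 1 and compound 3, as no pair shown changes the core in one place only.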